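Trifluoromethyl for chloro on the urea aryl group

This account rests on a few compounds, and the source may have more. Where it says the series, first, only, none or still open, it means among the compounds named here.

Measured compounds:
Compound 1, `O=C(Nc1cccc(-n2cc(-c3ccncc3)c(-c3ccc(Cl)c(O)c3)n2)c1)Nc1ccc(Cl)c(Cl)c1`: in a functional assay on SK-MEL-2 cells (Homo sapiens) for inhibition, read by sulforhodamine B assay, with a stated time of 48 h (on this read-out lower numbers stand for higher toxicity in this test and higher numbers for lower toxicity in this test), compound 1 gives > 32500 nM, a limit of the assay.
Compound 2, `COc1cc(-c2nn(-c3cccc(NC(=O)c4ccc(Cl)c(C(F)(F)F)c4)c3)cc2-c2ccncc2)ccc1Cl`: in this assay compound 2 gives > 32500 nM, also a limit.
Compound 3, `COc1cc(-c2nn(-c3cccc(NC(=O)c4ccccc4)c3)cc2-c2ccncc2)ccc1Cl`: in this assay compound 3 gives > 100000 nM, again a limit.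

Compound 1 thus stands only at a limit in this assay, and the two further values are limits as well (the limit of > 32500 nM in this assay, at which 2 of the 3 values shown sit, (the limit of > 100000 nM in this assay, at which 1 of the 3 values shown sits)). Compound 4, `O=C(Nc1cccc(-n2cc(-c3ccncc3)c(-c3ccc(Cl)c(O)c3)n2)c1)Nc1ccc(Cl)c(C(F)(F)F)c1`, differs from compound 1 in one place: trifluoromethyl in place of chloro on an aromatic carbon. Among the measured compounds shown here, the only step between measured compounds that differ in one place is a step that the two limits leave unreadable from compound 2 to compound 3, which the two limits leave unreadable; it concerns the amide aryl group of compound 2 and compound 3 and not the change made here. For the measured compounds named here, no measured step therefore bears on the change from compound 1 to compound 4 in this assay. With all three values at limits, no step beyond the scatter is expected, and a limit again is the most likely outcome. Compound 4 is expected at 50000 nM, with a range from 20000 nM to 150000 nM. The step this estimate means, a step that the limit leaves unreadable from compound 1 to compound 4, is expected to lie within the scatter.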

Compound 4, concentration lethal to 50% of the cells: 5840 nM
Compound 4: the middle estimate sits 8.6-fold (0.93 log units) above what was measured; the whole stated range lies above it.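

Trifluoromethyl in place of chloro, on the aromatic carbon ortho to a chloro group, gives an at least 5.5-fold lower number from compound 1 to compound 4 (0.74 log units; beyond the scatter) in this assay. This position of the urea aryl group is therefore the first place in the series where a single change gives a readable step, and compound 4 is the only compound shown with a number rather than a limit. Every other value shown is a limit, and no other step among these compounds can be read: the limit of > 32500 nM in this assay, at which 2 of the 4 values shown sit.

The compounds shown leave open whether another group at this position, such as methyl, nitrile or methoxy, would give a step of similar size. They also leave open whether the same change would give such a step with methoxy in place of the hydroxy group of compound 4.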